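The source may report more compounds than this note shows. Statements on the series, on what has been measured and on what is new or still open speak of the compounds shown alone.

Working notes on the phosphonate-bearing series

Compound 2 `C[C@](N)(COP(=O)(O)O)C(=O)Nc1ccc(OCCCCCc2ccccc2)cc1` carries a five-carbon chain from the aryl oxygen to a terminal benzyl group. In an assay on isolated protein for displacement of a labelled ligand from sphingosine 1-phosphate receptor 4 (Homo sapiens) (on this read-out higher numbers stand for weaker inhibition and lower numbers for stronger inhibition), compound 2 gives 3.6 nM. For the measured compounds named here, this is the only number so far: for compound 1 `C[C@](N)(COP(=O)(O)O)C(=O)Nc1ccc(OCCc2ccc(-c3cccs3)cc2)cc1`, the analogue whose chain ends in a thienyl-substituted phenyl, the entry in this assay reads "not determined" (no result reported), so compound 2 cannot be ranked against anything within the set.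

Compound 3 `C[C@](N)(COP(=O)(O)O)C(=O)Nc1ccc(OCCCCC2CCCCC2)cc1` differs from compound 2 in a single place: cyclohexyl in place of benzyl on a saturated chain carbon, four bonds along the chain from an oxygen on an aromatic ring. Going by the values given here, no measured pair in this assay shows the effect of replacing an aromatic terminal ring with a saturated one, so the step has to be judged from the structural change alone. The change keeps chain length, donor and acceptor count and charge unchanged, and the remaining terminus stays a hydrocarbon ring of the same size. A modest loss is expected rather than a gain, and the step of a 2.2-fold higher number from compound 2 to compound 3 (0.35 log units; beyond the scatter) is estimated to sit close to the edge of the usual scatter. Compound 3 is accordingly expected to give 8 nM in this assay, within a range of 2 nM to 30 nM.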

Compound 3, half-maximal inhibitory concentration: 8.3 nM
Beside the measured number, compound 3's estimate is 1.0-fold (0.02 log units) below it, and the stated range covers the measured number.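

In this assay, for the compounds shown here, the change gives a 2.3-fold higher number from compound 2 to compound 3 (0.36 log units; beyond the scatter), the first measured effect at this chain terminus and the first reading of an aromatic ring against a saturated one at this position. For this pair the aromatic ring is not needed for a nanomolar reading, as compound 3 still gives 8.3 nM, although the benzyl terminus of compound 2 gives the lower number and the gap lies beyond the usual scatter. Nothing available on these compounds accounts for the difference between the two terminal rings.

The compounds shown leave open how a terminal piperidine or tetrahydropyran ring would compare with cyclohexyl and benzyl at this place, and whether the same exchange would give a step of similar size on a shorter or a longer chain. They also leave open how a hydroxyl or a fluorine on the cyclohexyl ring would shift the number in this assay relative to the unsubstituted ring of compound 3.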